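Swapping amino for trifluoromethyl on a bridged tricyclic core

The source may hold more compounds than are shown below. What is called first, only, known or untested is meant among the compounds shown, and "the series" means these compounds.

Of the compounds shown here, two have so far been measured in an assay on HEK293 cells for binding affinity to Neuronal acetylcholine receptor; alpha4/beta2 (Homo sapiens); a lower number here means a stronger inhibitor, a higher number a weaker inhibitor. Compound 1 `c1ccc(-n2cnc3cc4c(cc32)C2CNCC4C2)cc1` gives 0.14 nM there. Compound 2 `Nc1ccc2c(c1)C1CNCC2C1`, built on a smaller core without the fused imidazole and its phenyl, gives 100 nM in this assay, which is the higher of the two numbers and lies well beyond the scatter from compound 1. Within the data shown here, no single-point step between measured compounds is available, so the direction of the next change has to be judged from the structures alone.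

Compound 3 `FC(F)(F)c1ccc2c(c1)C1CNCC2C1` differs from compound 2 in one place: trifluoromethyl in place of amino on an aromatic carbon. The step from compound 2 to compound 3 is expected to be small, a 1.7-fold lower number from compound 2 to compound 3 (0.22 log units; within the scatter), and may well stay within the scatter of this assay in either direction. On that basis compound 3 is estimated to give 60 nM in this assay, with a plausible range from 10 nM to 400 nM.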

Compound 3, inhibition constant: 0.33 nM
The estimate for compound 3 lay 180-fold (2.26 log units) above the measured number; the whole stated range lies above it.
By their numbers in this assay, from the lowest: compound 1; then compound 3; then compound 2.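

In this assay, among these compounds, trifluoromethyl in place of amino on an aromatic carbon gives a 300-fold lower number from compound 2 to compound 3 (2.48 log units; beyond the scatter), the first step here that isolates a single place on an otherwise unchanged core. It shows that this position, meta to a fused ring and para to a fused ring, is far from indifferent to the group it carries, with the exchange alone moving the number well beyond the scatter and favouring trifluoromethyl over amino. No supporting measurement bears on which feature of this exchange accounts for the step.

The single pair cannot separate the departure of the amino group, with its hydrogen-bond donor and acceptor, from the arrival of the larger trifluoromethyl group with neither, so the compounds shown leave open whether a methyl group, a chlorine atom or a nitrile on the same aromatic carbon would read like compound 3 or like compound 2. They also leave open whether the same exchange would have a comparable effect on the core of compound 1, which carries the fused imidazole and its phenyl.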